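Chloro-heteroaryl amides on the benzothiazolyl anilide core

This account rests on a few compounds, and the source may have more. Where it says the series, first, only, none or still open, it means among the compounds named here.

Compound 1 `O=C(Nc1cccc(-c2nc3ccccc3s2)c1)c1ccnc(Cl)c1` and compound 2 `O=C(Nc1cccc(-c2nc3ccccc3s2)c1)c1ccncc1Cl` share the same core and differ only in the chloropyridinyl group on the carbonyl carbon. In an ADME assay on Raji cells (Homo sapiens) for inhibition, with a stated time of 72 h (a lower number here means that less compound is needed, a higher number that more compound is needed for the effect), compound 1 gives > 25000 nM, which is a limit of the assay and not a number. In this assay compound 2 likewise gives > 25000 nM, again a limit of the assay. The step that the two limits leave unreadable from compound 1 to compound 2 therefore cannot be read, since both values rest on (the limit of > 25000 nM in this assay, at which 2 of the 2 values shown sit). Compound 2 thus stands at the limit of this assay, with no numerical value of its own.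

Compound 3 `O=C(Nc1cccc(-c2nc3ccccc3s2)c1)c1cnc(Cl)s1` carries the change (2-chloro-1,3-thiazol-5-yl in place of 3-chloropyridin-4-yl on a carbonyl carbon). The only measured step, from compound 1 to compound 2, is unreadable, so no measured step bears on the exchange of a chloropyridinyl for a chlorothiazolyl group, and no direction can be drawn from the data shown. With both neighbours sitting at the limit, compound 3 is expected to remain there too, so the step that the limit leaves unreadable from compound 2 to compound 3 is estimated as none beyond the scatter. The expected value for compound 3 in this assay is 30000 nM, estimated within 8000 nM to 100000 nM.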

Compound 3, half-maximal effective concentration: > 25000 nM
Compound 3 gave a limit, no number; the forecaster's own chance of this, stated with the estimate: 85%; the middle value does not contradict the limit.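

Compound 3 gives > 25000 nM in this assay, a limit of the assay and not a number. Going by these compounds alone, no step among compound 1, compound 2 and compound 3 can be read, since all three values rest on the same limit: the limit of > 25000 nM in this assay, at which 3 of the 3 values shown sit. The compounds shown leave open whether the 2-chloropyridin-4-yl, 3-chloropyridin-4-yl and 2-chloro-1,3-thiazol-5-yl groups differ at all in this assay.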